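The source may report more compounds than this note shows. Statements on the series, on what has been measured and on what is new or still open speak of the compounds shown alone.

Two compounds share one core and differ only in the group on one phenyl ring. Compound 1 `c1ccc(C2=NN(c3ccc(-c4ccccc4)nn3)C(c3ccccc3)C2)cc1` carries a hydrogen there, and in a functional assay on HepG2 cells (Homo sapiens) for antiproliferative activity, read by MTT assay, with a stated time of 24 h (on this read-out lower numbers stand for stronger inhibition and higher numbers for weaker inhibition), compound 1 gives 10000 nM. Compound 2 `Clc1ccc(C2=NN(c3ccc(-c4ccccc4)nn3)C(c3ccccc3)C2)cc1` carries a chloro instead, and in this assay compound 2 gives 8750 nM. The step of a 1.1-fold lower number from compound 1 to compound 2 (0.06 log units; within the scatter) shows that this exchange moves the number no more than repeated measurement would. Among the two numbers, compound 2 has the lower one, yet it sits within the scatter of compound 1, so no order between them can be claimed. Compound 3 `COc1ccc(C2=NN(c3ccc(-c4ccccc4)nn3)C(c3ccccc3)C2)cc1` is not yet measured. Its change from compound 2 is methoxy in place of chloro on an aromatic carbon. Going by the values given here, the only step that bears on this position, from compound 1 to compound 2, was within the scatter, so a change of similar, negligible size is expected in this assay, with no clear direction. For compound 3 the estimated value is 9000 nM, within a range from 4000 nM to 20000 nM, which means an expected step of a 1.0-fold higher number from compound 2 to compound 3 (0.01 log units; within the scatter).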

Compound 3, half-maximal inhibitory concentration: > 100000 nM
Compound 3: a limit, no number; the forecaster's own chance of this, stated with the estimate: 25%; middle value at least 11-fold (1.04 log units) away from the limit.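

In this assay compound 3 gives > 100000 nM, which is a limit of the assay and not a number. Even so, it shows that this position is not indifferent to what it carries: methoxy in place of chloro gives an at least 11-fold higher number from compound 2 to compound 3 (1.05 log units; beyond the scatter), and methoxy in place of hydrogen gives an at least 10-fold higher number from compound 1 to compound 3 (1.00 log units; beyond the scatter). Hydrogen and chloro could not be told apart here, so among the three groups shown, only methoxy stands clearly apart from the others.

Going by these compounds alone, with methoxy as the only oxygen-bearing group, the data cannot separate the part played by its oxygen from that of its carbon, and a methyl or hydroxyl group at this place would bear on that question. From the compounds shown here alone, how an amine or a longer chain such as ethoxy would behave here also stays open.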